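Methyl in Place of Hydrogen: Series Notes

The source may hold more compounds than are shown below. What is called first, only, known or untested is meant among the compounds shown, and "the series" means these compounds.

Measured so far in a functional assay (aorta) for antagonist activity, with Oryctolagus cuniculus as the target; a higher number here means a weaker inhibitor, a lower number a stronger inhibitor:
compound 1, `CCCCc1ccc(CN(C)S(=O)(=O)c2ccc(C)cc2)c(=O)n1Cc1ccc(-c2ccccc2-c2nn[nH]n2)cc1`, gives 8 nM;
compound 2, `CCCCc1ccc(CN(C)S(=O)(=O)c2ccccc2)c(=O)n1Cc1ccc(-c2ccccc2-c2nn[nH]n2)cc1`, gives 2 nM;
compound 3, `CCCCc1cccc(=O)n1Cc1ccc(-c2ccccc2-c2nn[nH]n2)cc1`, gives 4 nM.

Compound 1 differs from compound 2 by methyl in place of hydrogen on an aromatic carbon, and in this assay this gave a 4.0-fold higher number from compound 2 to compound 1 (0.60 log units; beyond the scatter). Compound 3 differs from compound 2 by hydrogen in place of (methyl(phenylsulfonyl)amino)methyl on an aromatic carbon, with a 2.0-fold higher number from compound 2 to compound 3 (0.30 log units; within the scatter). Compound 4, `CCCCc1ccc(C)c(=O)n1Cc1ccc(-c2ccccc2-c2nn[nH]n2)cc1`, is not yet measured; it differs from compound 3 by methyl in place of hydrogen on an aromatic carbon. This is the same kind of change as that from compound 2 to compound 1, but the place is not the same: there the change sat on an aromatic carbon of a six-membered aromatic ring of carbon only, para to a large group; here it sits on a six-membered aromatic ring with 1 nitrogen, ortho to a group of 1 heavy atom, two atoms from the ring nitrogen, meta to a large group and para to a butyl group. For compound 4 a step of a 2.0-fold higher number from compound 3 to compound 4 (0.30 log units; within the scatter) is expected in this assay, smaller than the earlier one because a 4.0-fold higher number from compound 2 to compound 1 (0.60 log units; beyond the scatter) arose at a different place. Compound 4 is thus estimated at 8 nM, between 3 nM and 20 nM.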

Compound 4, half-maximal inhibitory concentration: 7 nM
Estimate against measurement, compound 4: 1.1-fold (0.06 log units) above; measured number inside the range.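

In this assay, methyl in place of hydrogen gives steps of the same direction on the two cores, and their sizes cannot be told apart: the same change on two cores in this assay, a 4.0-fold higher number (0.60 log units; beyond the scatter) from compound 2 to compound 1 and a 1.8-fold higher number (0.24 log units; within the scatter) from compound 3 to compound 4, 2.3-fold (0.36 log units) apart, within the scatter of two such steps Taken alone, a 1.8-fold higher number from compound 3 to compound 4 (0.24 log units; within the scatter) does not establish an effect of the methyl on this core, while the earlier step does on its own core, so two pairs at different places show no conflict but do not prove that the change carries over generally. With the methyl-bearing compound 4 as reference, a 3.5-fold higher number from compound 2 to compound 4 (0.54 log units; beyond the scatter) is a modest step beyond the scatter, whereas a 1.1-fold lower number from compound 1 to compound 4 (0.06 log units; within the scatter) stays within it, so the effect of replacing the side chain depends on which of the two side chains is present.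

As far as these compounds go, whether an ethyl group or a chlorine on the same aromatic carbon would behave like the methyl remains open. Also open, from the compounds shown here alone, is whether a longer chain in place of the butyl group would alter the size of the methyl step.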